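Series notes: carboxymethoxyphenyl in place of allyloxy

The compounds below may be only part of what the source reports. "The series", "measured", "known", "first", "only" and "open" are said of these compounds alone.

Compound 3 `C=CCOC(c1ccc(OC)c(OC)c1OC)c1cccc2ccccc12` gives 9710 nM in a functional assay on A549 cells (Homo sapiens) for inhibition, read by sulforhodamine B assay, with a stated time of 48 h; on this read-out lower numbers stand for stronger inhibition and higher numbers for weaker inhibition. Compound 1 `COc1ccc(C(OCc2ccccc2)c2cccc3ccccc23)c(OC)c1OC` gives 13500 nM in this assay, and compound 2 `COc1ccc(C(c2ccc(O)cc2)c2cccc3ccccc23)c(OC)c1OC` gives 16400 nM in this assay. Compound 3 sits at the low end of these three numbers, yet a 1.4-fold lower number from compound 1 to compound 3 (0.14 log units; within the scatter) and a 1.7-fold lower number from compound 2 to compound 3 (0.23 log units; within the scatter) are both within the scatter, so the three are not separated. Compound 4 `COc1ccc(C(c2ccc(OCC(=O)O)cc2)c2cccc3ccccc23)c(OC)c1OC` differs from compound 3 by 4-(carboxymethoxy)phenyl in place of allyloxy on a saturated chain carbon bound to two aromatic carbons. The measured step that bears on this is a 1.7-fold lower number from compound 2 to compound 3 (0.23 log units; within the scatter) read in reverse, where a 4-hydroxyphenyl in this place stayed within the scatter of the allyloxy. Among the measured compounds shown here, the carboxymethoxy has no measured counterpart. The expected step of a 1.9-fold higher number from compound 3 to compound 4 (0.27 log units; within the scatter) in this assay is therefore small, not beyond the scatter. Compound 4 is estimated at 18000 nM, with a range of 7000 nM to 45000 nM.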

Compound 4, half-maximal inhibitory concentration: 16400 nM
Compound 4: the middle estimate sits 1.1-fold (0.04 log units) above what was measured; the measured number falls inside the stated range.
By their numbers in this assay, from the lowest: compounds 3, 1, 2 and 4 (each within the scatter of the next).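

Carboxymethyl in place of hydrogen on the oxygen on an aromatic ring gives no change at the digits printed from compound 2 to compound 4 (within the scatter) in this assay, so the added acid chain leaves the number where the free hydroxyl had it. On the saturated chain carbon bound to two aromatic carbons, the larger 4-(carboxymethoxy)phenyl is not separated from the smaller groups, with a 1.7-fold higher number from compound 3 to compound 4 (0.23 log units; within the scatter) and a 1.2-fold higher number from compound 1 to compound 4 (0.08 log units; within the scatter). No supporting data on this flat result are available. On these data alone, whether a methyl ester or an amine in place of the carboxylic acid would separate from these compounds remains open. The compounds shown also leave open whether any group at this place moves the number beyond the scatter.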